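A few compounds are considered here, and "the series" means these few. Any claim that something is new, unique, unknown or untested is made for them only; others in the source may bear on it.

Measured compounds:

Compound 1, `CC(C)c1ccc(NC(=O)N2CCN(c3ncccc3Cl)CC2)cc1`, gives 11.5 nM in a functional assay on HEK293 cells for antagonist activity at transient receptor potential cation channel subfamily V member 1 (Rattus norvegicus); on this read-out lower numbers stand for stronger inhibition and higher numbers for weaker inhibition.
Compound 2, `CC(C)c1ccc(NC(=O)N2CCN(c3ncccc3Br)CC2)cc1`, gives 4.6 nM.
Compound 3, `Cc1cccnc1N1CCN(C(=O)Nc2ccc(C(C)C)cc2)CC1`, gives 25.3 nM.

Compound 3 stands at the highest number of the three. The steps leading to it were a 2.2-fold higher number from compound 1 to compound 3 (0.34 log units; beyond the scatter) and a 5.5-fold higher number from compound 2 to compound 3 (0.74 log units; beyond the scatter), while between the two halogen analogues the step was a 2.5-fold lower number from compound 1 to compound 2 (0.40 log units; beyond the scatter). Compound 4, `CCc1cccnc1N1CCN(C(=O)Nc2ccc(C(C)C)cc2)CC1`, has not yet been measured. It differs from compound 3 by methyl in place of hydrogen on a saturated chain carbon bound to an aromatic carbon.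

Among the compounds with values here, none of the measured steps shares this change: all three concern a substituent on an aromatic carbon, not a saturated chain carbon. They do show that this position of the core affects this assay, and that among the three the bulkier halogen gave the lowest number. On that indirect footing compound 4 is expected to show a 1.7-fold lower number from compound 3 to compound 4 (0.23 log units; within the scatter), a modest move toward a lower number, though a result within the scatter would not be surprising. The estimate for compound 4 is 15 nM, with a range from 5 nM to 45 nM.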

Compound 4, half-maximal inhibitory concentration: 230 nM
For compound 4 the middle estimate is 15-fold (1.19 log units) below the measured one; the whole stated range lies below it.
By their numbers in this assay, from the lowest: compound 2; then compound 1; then compound 3; then compound 4.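

Methyl in place of hydrogen on a saturated chain carbon bound to an aromatic carbon gave a 9.1-fold higher number from compound 3 to compound 4 (0.96 log units; beyond the scatter) in this assay, a larger move than any step among the three earlier compounds. Measured against the halogens, ethyl in place of bromo gave a 50-fold higher number from compound 2 to compound 4 (1.70 log units; beyond the scatter), and ethyl in place of chloro gave a 20-fold higher number from compound 1 to compound 4 (1.30 log units; beyond the scatter). The rise in number from chloro to ethyl and from bromo to ethyl shows that the trend between the two halogens does not carry over to the alkyl groups, where the longer group, ethyl, has the higher number.

Nothing given here accounts for the size of this change. As far as these compounds go, it remains open whether a propyl chain would raise the number further, and whether a methoxy or an amine at this position would behave like the halogens or like the alkyl groups.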